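The compounds below may be only part of what the source reports. "The series", "measured", "known", "first", "only" and "open" are said of these compounds alone.

Measured so far:
- Compound 1, `COC(=O)c1cccc(-c2cnc(Nc3cccc(F)c3)o2)c1`: in an ADME assay on microsomes from liver (Homo sapiens) for metabolic stability, read by LC-MS, using NADPH (on this read-out lower numbers stand for a shorter-lived compound and higher numbers for a longer-lived compound), compound 1 gives < 0.0167 h, which is a limit of the assay rather than a number.
- Compound 2, `COC(=O)c1cccc(-c2cnc(Nc3ccc(F)cc3)o2)c1`: in this assay compound 2 gives < 0.0167 h, again a limit and not a number.

Both measured compounds therefore sit at the same point, (the limit of < 0.0167 h in this assay, at which 2 of the 2 values shown sit), and compound 2 stands there with no number of its own, only this limit. Within the data shown here, the one step between them, a step that the two limits leave unreadable from compound 1 to compound 2, cannot be read in size because both ends are limits.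

Compound 3, `NCc1cccc(-c2cnc(Nc3ccc(F)cc3)o2)c1`, is not yet measured. It differs from compound 2 in one place: aminomethyl in place of methoxycarbonyl on an aromatic carbon. The measured step changes only the fluorophenyl group, not the position where this change occurs, so it carries no direct information about the step from compound 2 to compound 3; the data give no measured basis for its size or direction. Compound 3 is expected to come out at about 0.1 h, within roughly 0.0167 h to 0.8 h, which would be the estimated step of an at least 5.9-fold higher number from compound 2 to compound 3 (0.77 log units; beyond the scatter), with a fair chance that this assay again reports only a limit.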

Compound 3, half-life: 0.818 h
Compound 3: middle estimate off by 8.2-fold (0.91 log units), on the low side; measured number above the stated range.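

Until now both values sat at a limit, so the step between compound 1 and compound 2 could not be read, and nothing showed how far the read-out could move in this series. The aromatic carbon carrying methoxycarbonyl now gives the first readable change: in this assay, aminomethyl in place of methoxycarbonyl gives an at least 48-fold higher number from compound 2 to compound 3 (1.69 log units; beyond the scatter). The compound 2 end of this step is a limit and not a number, so the step marks a floor for the change and not its full size: the limit of < 0.0167 h in this assay, at which 2 of the 3 values shown sit.

The compounds shown leave open whether the gain comes from losing methoxycarbonyl or from gaining aminomethyl, and a carboxylic acid, a primary amide or a longer chain ending in an amine on the same aromatic carbon would help to separate the two. They also leave open whether the 3-fluorophenyl group of compound 1 would give a similar result alongside aminomethyl, and the data offer no cause for the step, only its direction and its lower bound.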